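A few compounds are considered here, and "the series" means these few. Any claim that something is new, unique, unknown or untested is made for them only; others in the source may bear on it.

Working notes on the series. In a functional assay on the whole organism (plasma) with Mus musculus as the target, with a stated time of 15 days, at a dose of 30 mg/kg by the oral route (a lower number here means a weaker effect, a higher number a stronger effect of the compound at the dose given), compound 1 `Cc1ccc(CN2C(=O)S/C(=C\c3ccc(F)cc3)C2=O)cc1` gives 13.5%. Among the compounds with values here, compound 2 `Cc1ccc(CN2C(=O)S/C(=C\c3ccccc3Cl)C2=O)cc1` in this assay gives 43.3%, the highest of the two numbers measured so far; its nearest neighbour is compound 1, the one step recorded being a number 29.8 percentage points higher from compound 1 to compound 2 (beyond the scatter). Compound 3 `Cc1ccc(CN2C(=O)S/C(=C\c3ccc(O)cc3)C2=O)cc1` is not yet measured in this assay. It differs from compound 2 in one place: 4-hydroxyphenyl in place of 2-chlorophenyl on a double-bonded chain carbon bound to a double-bonded ring carbon. Within the data shown here, the only measured step that bears on this change is a number 29.8 percentage points higher from compound 1 to compound 2 (beyond the scatter), where a 2-chlorophenyl replaced a 4-fluorophenyl on the same double-bonded chain carbon bound to a double-bonded ring carbon and the number rose beyond the scatter. Among the measured compounds shown here, the change to compound 3 returns a 4-substituted phenyl to that place, now a 4-hydroxyphenyl rather than a 4-fluorophenyl, so no measured compound shows this group directly. A step downward in this assay of roughly the size seen is therefore expected, with wide uncertainty. Compound 3 is expected to give 20% in this assay, in the range 5% to 45%. The step expected from this is a number 23.3 percentage points lower from compound 2 to compound 3 (beyond the scatter).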

Compound 3, a percentage reported as activity, at one dose (the size of the read-out at that dose, not a potency): 37.3%
Beside the measured number, compound 3's estimate is 17.3 percentage points below it; the measured number falls inside the stated range.
By their numbers in this assay, from the lowest: compound 1; then compounds 3 and 2 (each within the scatter of the next).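

In this assay the exchange of 2-chlorophenyl for 4-hydroxyphenyl on a double-bonded chain carbon bound to a double-bonded ring carbon gives a number 6 percentage points lower from compound 2 to compound 3 (within the scatter) and so does not separate these two groups, which means that the earlier rise from compound 1 to compound 2 cannot be read as a need for 2-chlorophenyl at this place. Hydroxy in place of fluoro on an aromatic carbon gives a number 23.8 percentage points higher from compound 1 to compound 3 (beyond the scatter) and shows, among these compounds, that the low number belongs to the 4-fluorophenyl group of compound 1 and not to every phenyl group substituted at the 4 position, with compound 3 going against any such reading. No measurement shown here gives a reason for either step.

From the compounds shown here alone, whether the number follows the identity of the substituent or its place on the phenyl ring remains open, and 4-chlorophenyl and 2-hydroxyphenyl groups would test this directly. Also open, going by these compounds, is how far the tolerance at this place extends to other groups, such as 4-methoxyphenyl, 4-aminophenyl or 4-carboxyphenyl, on the shared core.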